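The source may hold more compounds than are shown below. What is called first, only, known or untested is meant among the compounds shown, and "the series" means these compounds.

Compound 1 `O=c1c(SC(=S)N2CCCCC2)coc2ccccc12`, 16300 nM; compound 2 `O=c1cc(CSC(=S)N2CCCCC2)oc2cc(Cl)ccc12`, 2500 nM; compound 3 `O=c1cc(CSC(=S)N2CCCCC2)oc2ccccc12`, 13700 nM.

All three were tested in a functional assay on SW480 cells (Homo sapiens) for antiproliferative activity, read by MTT assay, with a stated time of 72 h; on this read-out higher numbers stand for weaker inhibition and lower numbers for stronger inhibition. Compound 1 gives the highest number of the three: its gap to compound 3 lies within the scatter, its gap to compound 2 beyond it. Compound 3 and compound 2 share a core and differ in one place, (chloro in place of hydrogen on an aromatic carbon). That change made a 5.5-fold lower number from compound 3 to compound 2 (0.74 log units; beyond the scatter). Compound 4 `O=c1c(SC(=S)N2CCCCC2)coc2ccc(Cl)cc12` carries the same change on the core of compound 1, (chloro in place of hydrogen on an aromatic carbon). How the core of compound 1 differs from that of compound 3 is not broken down here. The cores differ, and the expected step is set a little short of the measured one. Resting on a 5.5-fold lower number from compound 3 to compound 2 (0.74 log units; beyond the scatter), the expected step is a 4.1-fold lower number from compound 1 to compound 4 (0.61 log units; beyond the scatter). Compound 4 is estimated at 4000 nM in this assay, with a likely range from 1500 nM to 12000 nM.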

Compound 4, half-maximal inhibitory concentration: > 25000 nM
Compound 4: a limit, no number (the forecaster's own chance of this, stated with the estimate: 5%); middle value at least 6.2-fold (0.79 log units) from the limit.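

In this assay compound 4 gives > 25000 nM, which is a limit of the assay and not a number. On the core of compound 1, chloro in place of hydrogen on an aromatic carbon gives an at least 1.5-fold higher number from compound 1 to compound 4 (0.18 log units; that floor lies within the scatter), so the drop in the number seen on the other core did not carry over: the same change on two cores in this assay, a 5.5-fold lower number (0.74 log units; beyond the scatter) from compound 3 to compound 2 and an at least 1.5-fold higher number (0.18 log units; that floor lies within the scatter) from compound 1 to compound 4, at least 8.4-fold (0.92 log units) apart, beyond the scatter of two such steps. The floor of this step alone does not show that chloro raises the number on this core, and two pairs do not show why the cores part.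

The compounds shown leave open whether a fluoro or a methoxy group in place of hydrogen would separate the two cores in the same way.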